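Chloro substitution and tolerance on THP-1 cells

The source may hold more compounds than are shown below. What is called first, only, known or untested is meant among the compounds shown, and "the series" means these compounds.

Compound 1 `COc1ccc(-c2cnc(NC(=O)c3ccccc3)n2C)cc1` and compound 3 `COc1ccc(-c2cnc(NC(=O)c3ccc(Cl)cc3)n2C)cc1` share one core, while compound 2 `Cn1c(-c2ccccc2)cnc1NC(=O)c1ncc[nH]1` rests on another; the difference between the two cores is not broken down here. In a toxicity assay on THP-1 cells (Homo sapiens) for inhibition (a lower number here means that less compound is tolerated, a higher number that more compound is tolerated), compound 1 gives only a limit of the assay, > 100000 nM. Compound 3 likewise reaches only a limit, > 100000 nM. Compound 2 also stands at a limit, > 100000 nM. The change chloro in place of hydrogen on an aromatic carbon thus yields a step that the two limits leave unreadable from compound 1 to compound 3, because of the limit of > 100000 nM in this assay, at which 3 of the 3 values shown sit. Compound 4 `Cn1c(-c2cccc(Cl)c2)cnc1NC(=O)c1ncc[nH]1` carries the same kind of change against compound 2, (chloro in place of hydrogen on an aromatic carbon), with the chloro meta to a large group rather than para to a large group. The step expected from compound 2 to compound 4 is a step that the limit leaves unreadable from compound 2 to compound 4 in this assay, resting on a step that the two limits leave unreadable from compound 1 to compound 3, which stayed unreadable at the limit. Compound 4 is therefore estimated at 150000 nM, between 60000 nM and 500000 nM.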

Compound 4, half-maximal cytotoxic concentration: 55000 nM
Compound 4: the middle estimate sits 2.7-fold (0.44 log units) above what was measured; the whole stated range lies above it.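

In this assay, the change from phenyl to 3-chlorophenyl gives an at least 1.8-fold lower number from compound 2 to compound 4 (0.25 log units; that floor lies within the scatter); compound 2 stands only at a limit, so the true step could be larger, but it is not shown to exceed the scatter. The same change on the core of compound 1 cannot be read, because both values there sit at a limit: the limit of > 100000 nM in this assay, at which 3 of the 4 values shown sit. The transfer of this change from one core to the other is therefore neither confirmed nor refuted, and the chloro of compound 4, meta to a large group, has no match in compound 3.

The compounds shown leave open whether tolerance falls reliably with chloro on either core. They also leave open how an amine or a carboxylic acid in that place would read.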